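The source may hold more compounds than are shown below. What is called first, only, known or untested is meant among the compounds shown, and "the series" means these compounds.

Series notes. Compound 1 `COc1ccc(C2=[N+]3C(=Nc4c(-c5ccccc5)c5c(n4[B-]3(F)F)-c3ccc(OCC(=O)N[C@@H](CC(=O)O)C(=O)O)cc3CC5)C(c3ccccc3)=C2I)cc1` is the reference; compound 2 `COc1ccc(C2=[N+]3C(=Nc4c(-c5ccccc5)c5c(n4[B-]3(F)F)-c3ccc(OCC(=O)N[C@@H](CCC(=O)O)C(=O)O)cc3CC5)C(c3ccccc3)=C2I)cc1` carries carboxymethyl in place of carboxy on a saturated chain carbon, two bonds along the chain from an amide-type nitrogen and a carbonyl carbon relative to it. Compound 3 `COc1ccc2c(c1)CCc1c(-c3ccccc3)c3n(c1-2)[B-](F)(F)[N+]1=C(c2ccc(OCC(=O)N[C@@H](CC(=O)O)C(=O)O)cc2)C(I)=C(c2ccccc2)C1=N3` has the same atoms as compound 1 joined differently; the difference between the two cores is not broken down here. Compound 4 `COc1ccc2c(c1)CCc1c(-c3ccccc3)c3n(c1-2)[B-](F)(F)[N+]1=C(c2ccc(OCC(=O)N[C@@H](CCC(=O)O)C(=O)O)cc2)C(I)=C(c2ccccc2)C1=N3` is not yet measured and stands to compound 3 as compound 2 stands to compound 1, with carboxymethyl in place of carboxy on a saturated chain carbon, two bonds along the chain from an amide-type nitrogen and a carbonyl carbon at the same place, word for word.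

In a toxicity assay on B16-F10 cells (Mus musculus) for cytotoxicity, read by CCK-8 assay, with stated times of 16 h and 24 h (a higher number here means a weaker inhibitor, a lower number a stronger inhibitor), compound 1 gives 65 nM, compound 2 gives 159 nM and compound 3 gives 126 nM. For the measured compounds named here, the one step between compounds differing in a single place is a 2.4-fold higher number from compound 1 to compound 2 (0.39 log units; beyond the scatter); the change occurs twice among the four compounds. Compound 3 sits within scatter of both compound 1 and compound 2, so no order among the three is claimed.

Going by the values given here, for compound 4 the step of a 2.4-fold higher number from compound 3 to compound 4 (0.38 log units; beyond the scatter) is expected in this assay, resting on the only measured instance of this change, a 2.4-fold higher number from compound 1 to compound 2 (0.39 log units; beyond the scatter), applied to compound 3 at 126 nM. Among the compounds with values here, the estimate for compound 4 is 300 nM, with a range of 150 nM to 600 nM allowing for scatter and for the single precedent.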

Compound 4, half-maximal inhibitory concentration in the B16-F10 assay: 212 nM
Compound 4: middle estimate off by 1.4-fold (0.15 log units), on the high side, and the stated range covers the measured number.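

In the B16-F10 assay, carboxymethyl in place of carboxy on a saturated chain carbon, two bonds along the chain from an amide-type nitrogen and a carbonyl carbon, gives a 1.7-fold higher number from compound 3 to compound 4 (0.23 log units; within the scatter), whereas the same change on the other core gives a 2.4-fold higher number from compound 1 to compound 2 (0.39 log units; beyond the scatter). Set side by side, the two steps do not differ: the same change on two cores in the B16-F10 assay, a 2.4-fold higher number (0.39 log units; beyond the scatter) from compound 1 to compound 2 and a 1.7-fold higher number (0.23 log units; within the scatter) from compound 3 to compound 4, 1.5-fold (0.16 log units) apart, within the scatter of two such steps. The two pairs are compatible with one step size carried from one core to the other, but they do not establish a real step on the core of compound 3 taken alone, and two pairs make no rule for any other core.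

Open, as far as these compounds go, is how a longer chain, or an amine in place of the carboxy group at the same place, would read in the B16-F10 assay on either core. From the compounds shown here alone, in a physicochemical assay for lipophilicity (on this read-out higher numbers stand for higher lipophilicity and lower numbers for lower lipophilicity), compound 3 gives -0.73 and compound 4 gives -0.71; the change gives a number 0.02 log units higher from compound 3 to compound 4 (within the scatter), and whether the core of compound 1 behaves alike on that read-out stays open.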